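Naphthyl for phenyl on the sulfonamide of a thiazolone series

The source may hold more compounds than are shown below. What is called first, only, known or untested is meant among the compounds shown, and "the series" means these compounds.

Compound 1 `O=c1sc2cc(S(=O)(=O)c3ccccc3)ccc2n1CCN1CCCCC1` gives 11% in an assay on HEK293 cells for displacement of a labelled ligand from 5-hydroxytryptamine receptor 6 (Homo sapiens), read by radioligand binding, with a stated time of 60 min, tested at 100 nM; a higher number here means more inhibition at the concentration tested (going by the name of the read-out), a lower number less inhibition.
Compound 2 `CN(c1ccccc1)S(=O)(=O)c1ccc2c(c1)sc(=O)n2CCN1CCCC1` gives 10% in this assay.
Compound 3 `CN(c1ccccc1)S(=O)(=O)c1ccc2c(c1)sc(=O)n2CCN1CCCCC1` gives 0% in this assay.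

Compound 3 stands lowest of the three numbers; compound 2 sits nearest, within the scatter, while compound 1 is furthest, beyond it. Compound 4 `CN(c1cccc2ccccc12)S(=O)(=O)c1ccc2c(c1)sc(=O)n2CCN1CCCCC1` differs from compound 3 in one place: naphthalen-1-yl in place of phenyl on a sulfonamide nitrogen. Neither measured step touches this position. The step of a number 11 percentage points lower from compound 1 to compound 3 (beyond the scatter) changed the group on the sulfonyl sulfur, and the step of a number 10 percentage points lower from compound 2 to compound 3 (within the scatter) changed the amine ring; both were small. Nothing measured here speaks to the aryl group on the sulfonamide nitrogen, so the step of a number 10 percentage points higher from compound 3 to compound 4 (within the scatter) is expected to be small, if anything slightly upward. Compound 4 is estimated at 10%, between 0% and 30%.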

Compound 4, a percentage reported as inhibition, at one concentration (the size of the read-out at that concentration, not a potency): 14%
Compound 4: the middle estimate sits 4 percentage points below what was measured; the measured number falls inside the stated range.
By their numbers in this assay, from the lowest: compounds 3, 2, 1 and 4 (each within the scatter of the next, the first and the last beyond it).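

The aryl group on the sulfonamide nitrogen proves able to shift the number in this assay: replacing phenyl with naphthalen-1-yl gives a number 14 percentage points higher from compound 3 to compound 4 (beyond the scatter), a modest step. Even so, compound 4 reaches only 14% at the concentration tested, so the inhibition remains small. No evidence at hand accounts for this step. On these data alone, whether naphthalen-2-yl or a methoxy-bearing phenyl would behave similarly on this nitrogen remains open. So does whether naphthalen-1-yl would give a similar step alongside the pyrrolidin-1-yl group of compound 2.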